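Replacing an aryl amide with an aryl urea on a shared core

This account rests on a few compounds, and the source may have more. Where it says the series, first, only, none or still open, it means among the compounds named here.

Of the compounds shown here, three of one shared core have been measured in a functional assay on T47D cells (Homo sapiens) for inhibition, read by sulforhodamine B assay, with a stated time of 48 h; a lower number here means a stronger inhibitor of growth, a higher number a weaker inhibitor of growth. Compound 1 `O=C(Nc1cccc(-n2cc(-c3ccncc3)c(-c3ccc(Cl)c(O)c3)n2)c1)Nc1ccc(Cl)c(Cl)c1` gives 1550 nM. Compound 2 `COc1cc(-c2nn(-c3cccc(NC(=O)c4ccc(Cl)c(C(F)(F)F)c4)c3)cc2-c2ccncc2)ccc1Cl` gives 2050 nM, and compound 3 `COc1cc(-c2nn(-c3cccc(NC(=O)c4cccc(C(F)(F)F)c4)c3)cc2-c2ccncc2)ccc1Cl` gives 2550 nM. Compound 3 thus holds the highest of the three numbers, yet its gaps to the other two fall within the scatter, so the three are not separated by this assay. Going by the values given here, the only single-point step among them, a 1.2-fold higher number from compound 2 to compound 3 (0.09 log units; within the scatter), is also within the scatter.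

Compound 4 `COc1cc(-c2nn(-c3cccc(NC(=O)Nc4ccc(Cl)c(C(F)(F)F)c4)c3)cc2-c2ccncc2)ccc1Cl` has not yet been measured. It differs from compound 3 in one place: (4-chloro-3-(trifluoromethyl)phenyl)amino in place of 3-(trifluoromethyl)phenyl on a carbonyl carbon. The change puts the chloro group back and at the same time inserts an extra nitrogen-bound hydrogen between the carbonyl carbon and the aromatic ring. Compound 1 already carries such an arrangement, though with a different aromatic ring, and its value lies within the scatter of both compound 2 and compound 3. Among the compounds with values here, no measured step isolates the effect of the inserted amino group, so the expectation for compound 4 rests on the narrow spread of all three numbers: the step of a 1.6-fold lower number from compound 3 to compound 4 (0.20 log units; within the scatter) is expected to stay within the scatter. Compound 4 is therefore estimated at 1600 nM, with a plausible range from 600 nM to 4500 nM.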

Compound 4, concentration for 50% growth inhibition: 1230 nM
For compound 4 the middle estimate is 1.3-fold (0.11 log units) above the measured one, within the range that was stated.
By their numbers in this assay, from the lowest: compounds 4, 1, 2 and 3 (each within the scatter of the next, the first and the last beyond it).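

In this assay, a 2.1-fold lower number from compound 3 to compound 4 (0.32 log units; beyond the scatter) is the only step shown that lies beyond the scatter, although it is modest, and it brings in the chloro group and the amino group together. The cleaner comparison is a 1.7-fold lower number from compound 2 to compound 4 (0.22 log units; within the scatter). Going by these compounds alone, both compounds carry the same chloro- and trifluoromethyl-substituted ring, so the inserted amino group is the only change on the carbonyl carbon; this step stays within the scatter, as does the loss of the chloro group alone in a 1.2-fold higher number from compound 2 to compound 3 (0.09 log units; within the scatter), so neither change, taken by itself, is separated by this assay, and turning the amide into a urea is tolerated here without a clear gain. No measurement shown explains these numbers.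

The compounds shown leave open how a urea bearing the plain 3-(trifluoromethyl)phenyl ring would compare, which would show whether the chloro group matters once the amino group is present. They also leave open whether an oxygen atom or a methylene group in place of the inserted amino group, or a nitrile in place of the trifluoromethyl group, would give a similar number.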